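From the phenol to its methyl ether

This account rests on a few compounds, and the source may have more. Where it says the series, first, only, none or still open, it means among the compounds named here.

Measured compounds in a functional assay on MDA-MB-231 cells (Homo sapiens) for antiproliferative activity, read by MTT assay, with a stated time of 48 h; a lower number here means a stronger inhibitor, a higher number a weaker inhibitor:
compound 1 `N#Cc1ncn(-c2ccc(F)cc2)c1/N=C/c1ccc([N+](=O)[O-])cc1`: 13400 nM
compound 2 `COc1cc(/C=N/c2c(C#N)ncn2-c2ccc(F)cc2)ccc1O`: 13600 nM
compound 3 `N#Cc1ncn(-c2ccc(F)cc2)c1/N=C/c1ccc(O)cc1`: 16300 nM

Compound 3 gives the highest of the three numbers in this assay, but neither neighbour is separated from it: the step of a 1.2-fold higher number from compound 1 to compound 3 (0.09 log units; within the scatter) and the step of a 1.2-fold higher number from compound 2 to compound 3 (0.08 log units; within the scatter) both stay within the scatter, so the three compounds are not distinguished by these data.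

Compound 4 `COc1ccc(/C=N/c2c(C#N)ncn2-c2ccc(F)cc2)cc1` differs from compound 3 by methyl in place of hydrogen on an oxygen on an aromatic ring. Within the data shown here, the nearest precedent is the step from compound 2 to compound 3, which also involves a methoxy group on the same ring and stays within the scatter, as does the step from compound 1 to compound 3, where nitro and hydroxy give indistinguishable numbers. Three different substituents on that ring have given much the same result, so no step beyond the scatter is expected here; the estimated step of a 1.2-fold lower number from compound 3 to compound 4 (0.07 log units; within the scatter) is accordingly small. Compound 4 is expected to give about 14000 nM, within a range from 7000 nM to 28000 nM.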

Compound 4, half-maximal inhibitory concentration: 17100 nM
For compound 4 the middle estimate is 1.2-fold (0.09 log units) below the measured one; the range from low to high includes it.
By their numbers in this assay, from the lowest: compounds 1, 2, 3 and 4 (each within the scatter of the next).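

In this assay, among these compounds, the change from 4-hydroxyphenyl to 4-methoxyphenyl gives a 1.0-fold higher number from compound 3 to compound 4 (0.02 log units; within the scatter) and stays within the scatter, so this is the first direct evidence that methyl in place of hydrogen on this oxygen does not separate the two compounds. Exchanging nitro for methoxy on the aromatic carbon gives a 1.3-fold higher number from compound 1 to compound 4 (0.11 log units; within the scatter) and is also within the scatter, which adds a third pair of substituents at this place on the ring that the assay does not distinguish, with hydroxy, methoxy and nitro all giving comparable numbers. No measurement shown here accounts for this lack of separation.

On these data alone, whether an amine or a carboxylic acid on that aromatic carbon would give a number beyond the scatter remains open. Also open, as far as these compounds go, is whether a change elsewhere on the shared core would do so.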